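The source may hold more compounds than are shown below. What is called first, only, known or untested is meant among the compounds shown, and "the series" means these compounds.

Measured in an assay for binding affinity to Adrenergic receptor alpha-1 (Rattus norvegicus); a higher number here means a weaker inhibitor, a lower number a stronger inhibitor:

compound 1 `O=c1[nH]c2cc[nH]c2c(=O)n1CCCN1CCN(c2ccccc2Cl)CC1`: 59.8 nM
compound 2 `O=c1[nH]c2cc(-c3ccccc3)[nH]c2c(=O)n1CCCN1CCN(c2ccccc2Cl)CC1`: 62.4 nM
compound 3 `COc1ccccc1N1CCN(CCCn2c(=O)[nH]c3cc(-c4ccc(C)cc4)[nH]c3c2=O)CC1`: 47.9 nM

Compound 3 holds the lowest of the three numbers in this assay, but its gaps to compound 1 and to compound 2 are both within the scatter, so the three compounds cannot be told apart on these numbers.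

Compound 4 `Cc1ccc(-c2cc3[nH]c(=O)n(CCCN4CCN(c5ccccc5Cl)CC4)c(=O)c3[nH]2)cc1` differs from compound 3 in one place: chloro in place of methoxy on an aromatic carbon. Among the compounds with values here, the only measured step, a 1.0-fold higher number from compound 1 to compound 2 (0.02 log units; within the scatter), concerns a different position of the core and is within the scatter; it says nothing direct about the exchange at hand. What the numbers do show is that compound 1 and compound 2, which both carry the 2-chlorophenyl, sit within the scatter of compound 3, which carries the 2-methoxyphenyl, so nothing in the measured set points to a shift in either direction beyond the scatter for this exchange. The expected step from compound 3 to compound 4 is therefore a 1.1-fold higher number from compound 3 to compound 4 (0.06 log units; within the scatter), no change beyond the scatter. On that basis compound 4 is estimated at 55 nM, with a range from 25 nM to 120 nM.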

Compound 4, inhibition constant: 110 nM
Compound 4: middle estimate off by 2.0-fold (0.30 log units), on the low side, and the stated range covers the measured number.
By their numbers in this assay, from the lowest: compounds 3, 1, 2 and 4 (each within the scatter of the next, the first and the last beyond it).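

Within the data shown here, with the 4-methylphenyl group held constant on the shared core, 2-chlorophenyl in place of 2-methoxyphenyl gives a 2.3-fold higher number from compound 3 to compound 4 (0.36 log units; beyond the scatter) in this assay, a modest step and the only one so far that lies beyond the scatter, seen in this single pair. The other two new steps stay within the scatter: methyl added to the phenyl group gives a 1.8-fold higher number from compound 2 to compound 4 (0.25 log units; within the scatter), and 4-methylphenyl in place of hydrogen gives a 1.8-fold higher number from compound 1 to compound 4 (0.26 log units; within the scatter), so compound 1, compound 2 and compound 4, which all carry 2-chlorophenyl, are not separated by these changes on the core. Nothing available bears on why the exchange of methoxy for chloro shows up in this pair.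

Whether the same step appears with the core of compound 1 or compound 2 remains open: 2-methoxyphenyl is shown only with the 4-methylphenyl group in place. Also open, from the compounds shown here alone, is how other groups at this place on the six-membered aromatic ring, such as fluoro, ethoxy or an amine, would compare with methoxy and chloro.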